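The compounds below may be only part of what the source reports. "The series", "measured", "known", "first", "only" and "open" are said of these compounds alone.

Compound 1 `C=CC[C@@]12C[C@@H](C(=O)OC)N3[C@@H]1N(C(=N)C31CCCCC1)c1ccccc12` gives 23500 nM in a functional assay on HT-29 cells (Homo sapiens) for cytotoxicity, read by sulforhodamine B assay, with a stated time of 48 h; a higher number here means a weaker inhibitor of growth, a lower number a stronger inhibitor of growth. Compound 2 `COC(=O)[C@@H]1C[C@@]2(CC=C(C)C)c3ccccc3N3C(=N)[C@H](Cc4ccccc4)N1[C@H]32` gives 24100 nM in this assay, close to compound 1. For compound 3 `COC(=O)[C@@H]1C[C@@]2(CC=C(C)C)c3ccccc3N3C(=N)[C@H](c4ccccc4)N1[C@H]32`, this assay reports only a limit, > 100000 nM. The step of an at least 4.1-fold higher number from compound 2 to compound 3 (0.61 log units; beyond the scatter) is therefore known only as a bound, which rests on (the limit of > 100000 nM in this assay, at which 1 of the 3 values shown sits). Compound 3 thus stands at the weak end of the numbers shown, beyond both measured values. Compound 4 `COC(=O)[C@@H]1C[C@@]2(CC=C(C)C)c3ccccc3N3C(=N)[C@H](C(C)(C)C)N1[C@H]32` differs from compound 3 in one place: tert-butyl in place of phenyl on a saturated ring carbon. Going by the values given here, the only measured step that touches this saturated ring carbon is an at least 4.1-fold higher number from compound 2 to compound 3 (0.61 log units; beyond the scatter), and it shows that a change there can move the number by a large amount. With compound 3 at the limit, the direction of the change to compound 4 cannot be read from the numbers. For compound 4 the expected step is an at least 1.2-fold lower number from compound 3 to compound 4 (0.09 log units; that floor lies within the scatter). Compound 4 is therefore estimated at 80000 nM in this assay, with a range from 25000 nM to 300000 nM.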

Compound 4, concentration for total growth inhibition: > 100000 nM
Compound 4: a limit, no number; the forecaster's own chance of this, stated with the estimate: 50%; middle value at least 1.2-fold (0.09 log units) from the limit.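

In this assay, compound 4 gives > 100000 nM, which is a limit and not a number. At this saturated ring carbon, the result is an at least 4.1-fold higher number from compound 2 to compound 4 (0.61 log units; beyond the scatter), so the rise seen with phenyl also appears with tert-butyl, a group with no ring, and a six-membered aromatic ring of carbon only directly on this carbon is not required for it. The step between phenyl and tert-butyl cannot be read, because both compounds rest on the same bound: the limit of > 100000 nM in this assay, at which 2 of the 4 values shown sit.

On these data alone, how far compound 3 and compound 4 lie past that limit stays open, so phenyl and tert-butyl cannot be ranked against each other. Also open, as far as these compounds go, is what a longer chain such as phenethyl, an amine or a carboxylic acid would give on this carbon.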